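The source may report more compounds than this note shows. Statements on the series, on what has been measured and on what is new or still open speak of the compounds shown alone.

In a functional assay on Bel-7402 cells (Homo sapiens) for inhibition, read by MTT assay, with a stated time of 24 h, tested at 10 ug/mL (a lower number here means less inhibition of growth, a higher number more inhibition of growth at the concentration tested), compound 1 `O=C(O)CCCCC(CCSC(=O)c1ccccc1)SC(=O)c1ccccc1` gives 2.76% and compound 2 `O=C(CCCCC(CCSC(=O)c1ccccc1)SC(=O)c1ccccc1)Nc1ccccc1Cl` gives 6.63%, so these two values lie within the scatter of each other. Among the compounds with values here, the only measured step, a number 3.9 percentage points higher from compound 1 to compound 2 (within the scatter), is small. Compound 3 `O=C(CCCCC(CCSC(=O)c1ccccc1)SC(=O)c1ccccc1)Nc1ccc(Cl)cc1` differs from compound 2 in one place: 4-chlorophenyl in place of 2-chlorophenyl on an amide-type nitrogen. Within the data shown here, no measured step exchanges one chlorophenyl for another, so that small step is the only guide and the data give no reason to expect a shift beyond the scatter. The expected change is a number 0.4 percentage points higher from compound 2 to compound 3 (within the scatter). For compound 3 the estimate is 7%, with an expected range from 0% to 15%.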

Compound 3, percent growth inhibition at one concentration: 4.87%
For compound 3 the middle estimate is 2.1 percentage points above the measured one, within the range that was stated.
By their numbers in this assay, from the lowest: compounds 1, 3 and 2 (each within the scatter of the next).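

In this assay, the two chlorophenyl groups on the amide-type nitrogen can now be compared directly, and the exchange gives a number 1.8 percentage points lower from compound 2 to compound 3 (within the scatter) at this position. With (4-chlorophenyl)amino in place of hydroxy on the carbonyl carbon, the result is a number 2.1 percentage points higher from compound 1 to compound 3 (within the scatter) and so both chlorophenyl amides stay close to the starting compound. Nothing available explains these small differences.

Still open, on these data alone, is whether an unsubstituted phenyl, a methoxyphenyl or a simple alkyl chain on this nitrogen would shift growth inhibition beyond the scatter.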